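The compounds below may be only part of what the source reports. "The series", "measured", "known", "first", "only" and "open" are said of these compounds alone.

Working notes on the series. In a functional assay on A549 cells (Homo sapiens) for inhibition, read by sulforhodamine B assay, with a stated time of 48 h (on this read-out lower numbers stand for stronger inhibition and higher numbers for weaker inhibition), compound 1 (`CCO[C@H]1C[C@@H](c2coc3ccccc3c2=O)N(c2ccccc2)O1`) reads > 60000 nM, which is a limit of the assay and not a number. For the measured compounds named here, compound 2 (`CCO[C@H]1C[C@@H](c2coc3ccc(F)cc3c2=O)N(c2ccccc2)O1`) gives 26400 nM, the only true number so far.

Compound 3 (`CCO[C@H]1C[C@@H](c2coc3ccc(C)cc3c2=O)N(c2ccccc2)O1`) has methyl in place of fluoro on an aromatic carbon. The group sits on a six-membered aromatic ring of carbon only, part of a fused system of two rings, meta to a fused ring and para to a fused ring.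

Going by the values given here, one measured step bears on this carbon: an at least 2.2-fold lower number from compound 1 to compound 2 (0.35 log units; beyond the scatter). Its size is open on one side, as the limit of > 60000 nM in this assay, at which 1 of the 2 values shown sits, shows. Among the compounds with values here, no measured step compares methyl with fluoro or with hydrogen, so the step from compound 1 to compound 2 gives only a rough scale for a change at this carbon, and no direction for the new group.

In this assay, no change beyond the scatter is expected, although a reading at the limit remains possible. The expected change is a 1.1-fold higher number from compound 2 to compound 3 (0.06 log units; within the scatter). For compound 3 the estimate is 30000 nM, with an expected range of 13000 nM to 65000 nM.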

Compound 3, half-maximal inhibitory concentration: 20700 nM
Estimate against measurement, compound 3: 1.4-fold (0.16 log units) above, and the stated range covers the measured number.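

In this assay, the new result shows that exchanging fluoro for methyl on this aromatic carbon makes no measurable difference, with a 1.3-fold lower number from compound 2 to compound 3 (0.11 log units; within the scatter). Methyl in place of hydrogen gives an at least 2.8-fold lower number from compound 1 to compound 3 (0.46 log units; beyond the scatter), so the gain seen with fluoro is no longer tied to a single group: two different single-atom substituents at this carbon now lie beyond the scatter from compound 1. The size of that gain remains open on one side, since compound 1 stands at a limit of the assay and not at a number: the limit of > 60000 nM in this assay, at which 1 of the 3 values shown sits.

From the compounds shown here alone, what a methoxy group, an amine, a carboxylic acid or a longer chain such as propyl would do at this carbon remains open, as does whether any group here can bring the number well below those of compound 2 and compound 3. All three compounds also share the rest of the core, so the compounds shown give no reading for a change on the phenyl ring or at the ethoxy group.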